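Mirror image of compound 1: expected stability

This account rests on a few compounds, and the source may have more. Where it says the series, first, only, none or still open, it means among the compounds named here.

Two compounds have readings so far in an in vitro ADME assay on microsomes from liver (Homo sapiens) for metabolic stability, read by LC-MS, tested at 3 uM; on this read-out lower numbers stand for a shorter-lived compound and higher numbers for a longer-lived compound. Going by the values given here, compound 1 (`CN1C[C@@H]2CCC[C@]2(c2ccc3ccccc3c2)C1`) gives 0.6 h, the only true number.

Compound 2 (`Clc1ccc(C[C@@]23CCCC[C@@H]2CNC3)cc1Cl`) reads > 5 h, which is a limit of the assay and not a number.

Compound 1 therefore provides the only numerical anchor, and it lies short of the limit reached by compound 2. Compound 3 (`CN1C[C@H]2CCC[C@@]2(c2ccc3ccccc3c2)C1`) has not yet been measured in this assay. Its relation to compound 1 is the two compounds have the same atoms and bonds and differ only in configuration as drawn: 2 of 2 stereo elements differ (all stereocentres are inverted: mirror images); a stereocentre at a saturated ring carbon is drawn R in compound 1 and S in compound 3; a stereocentre at a saturated ring carbon is drawn S in compound 1 and R in compound 3. The two compounds have the same atoms and bonds and are mirror images, with all stereocentres inverted.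

Among the compounds with values here, no mirror-image pair has been measured, so the data give no direct guide to the size of such a step. The working expectation is no step beyond the usual scatter, with neither direction favoured, and it starts from compound 1 at 0.6 h. Within the data shown here, the range is kept wide on both sides because only one number is available.

The expected result is a 1.2-fold higher number from compound 1 to compound 3 (0.07 log units; within the scatter).

For compound 3 the estimated half-life is 0.7 h, with an expected range of 0.3 h to 2 h.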

Compound 3, half-life: 0.317 h
Beside the measured number, compound 3's estimate is 2.2-fold (0.34 log units) above it, and the stated range covers the measured number.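

In this assay the series now has its first readable step, and it is a pure mirror-image change at two stereocentres on saturated ring carbons: a 1.9-fold lower number from compound 1 to compound 3 (0.28 log units; within the scatter). Inverting both stereocentres together therefore leaves the two half-lives within the usual scatter of each other, so this pair gives no sign that the drawn configuration separates the mirror images in this read-out, and the comparison is a clean one: the fact that compounds 1 and 3 differ only in the configuration as drawn. Compound 2 reads > 5 h, which is a limit of the assay and not a number, and it differs from the other compounds in more than one place, so it adds nothing to this step.

One mirror-image pair cannot show whether the same holds for other members of the series, or whether inverting only one of the two stereocentres would give a similar reading. Also open, as far as these compounds go, is how this assay would respond to a single change on the shared core, such as adding a carboxylic acid, an amide or a longer chain.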